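This account rests on a few compounds, and the source may have more. Where it says the series, first, only, none or still open, it means among the compounds named here.

Within the data shown here, in a functional assay on HCT-116 cells (Homo sapiens) for inhibition, with a stated time of 72 h (on this read-out higher numbers stand for weaker inhibition and lower numbers for stronger inhibition), compound 2 (`NC1CCC(Nc2nc(NCc3ccc(-c4ccco4)cc3)c3ncn(C4CCCC4)c3n2)CC1`) gives 129 nM and holds the lowest of the two numbers so far, while compound 1 (`NC1CCC(Nc2nc(NCc3ccc(-c4cccc(F)c4)cc3)c3ncn(C4CCCC4)c3n2)CC1`) gives 551 nM on the same read-out. Compound 3 (`Nc1ccccc1CNc1nc(NC2CCC(N)CC2)nc2c1ncn2C1CCCC1`) is still unmeasured and differs from compound 2 by 2-aminophenyl in place of 4-(furan-2-yl)phenyl on a saturated chain carbon bound to a nitrogen on an aromatic ring in one place, with 2-aminophenyl in place of 4-(furan-2-yl)phenyl on a saturated chain carbon bound to a nitrogen on an aromatic ring. Among the measured compounds shown here, the only measured step, furan-2-yl in place of 3-fluorophenyl, is a 4.3-fold lower number from compound 1 to compound 2 (0.63 log units; beyond the scatter) and counts as modest, so it offers only a rough guide to this larger change. A modest move to a higher number in this assay is expected, and the estimated step is a 2.3-fold higher number from compound 2 to compound 3 (0.37 log units; beyond the scatter) with wide uncertainty. Compound 3 is estimated at 300 nM (expected range 60 nM to 1500 nM).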

Compound 3, half-maximal inhibitory concentration: 2300 nM
Compound 3: middle estimate off by 7.7-fold (0.88 log units), on the low side; measured number outside the range, above it.
By their numbers in this assay, from the lowest: compound 2; then compound 1; then compound 3.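

In this assay, 2-aminophenyl in place of 4-(furan-2-yl)phenyl gives an 18-fold higher number from compound 2 to compound 3 (1.25 log units; beyond the scatter), a large loss of inhibition and a far bigger step than the earlier swap of one outer ring for another. The entering group has one aromatic ring rather than two and adds a hydrogen-bond donor, so both changes arrive together at this position. Nothing available explains the loss. Which change matters remains open, and a plain phenyl group, without the amine, would help to separate them.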